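A few compounds are considered here, and "the series" means these few. Any claim that something is new, unique, unknown or untested is made for them only; others in the source may bear on it.

Measured so far in an assay on cells (Oocyte) for negative allosteric modulation of glutamate receptor ionotropic, NMDA 2D (Rattus norvegicus), read by two-electrode voltage clamp; on this read-out lower numbers stand for stronger inhibition and higher numbers for weaker inhibition:
compound 1, `O=C(O)CCC(=O)N1N=C(c2c(-c3ccccc3)c3cc(Cl)ccc3[nH]c2=O)CC1c1ccc([N+](=O)[O-])cc1`: 1100 nM
compound 2, `COc1ccc(-c2c(C3=NN(C(=O)CCC(=O)O)C(c4ccc(Cl)cc4)C3)c(=O)[nH]c3ccccc23)cc1`: 2300 nM

Compound 2 gives the highest of the two numbers in this assay; its nearest neighbour is compound 1, whose number is lower by a margin beyond the usual scatter, so on these two values compound 2 is the weaker inhibitor of the pair. Among the compounds with values here, no two measured compounds differ in only one place, so no measured step can be set beside the change now considered.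

Compound 3, `O=C(O)CCC(=O)N1N=C(c2c(-c3ccc(Cl)c(Cl)c3)c3ccccc3[nH]c2=O)CC1c1ccc(Cl)cc1`, is still to be measured in this assay. It differs from compound 2 in one place: 3,4-dichlorophenyl in place of 4-methoxyphenyl on an aromatic carbon, a 3,4-dichlorophenyl in place of a 4-methoxyphenyl on an aromatic carbon. The measured pair gives no direct guide to what this exchange does, as compound 1 and compound 2 differ in more than one place. The expectation therefore rests on where compound 2 stands, and the step from compound 2 to compound 3 is estimated as a 1.5-fold lower number from compound 2 to compound 3 (0.19 log units; within the scatter), a modest move toward a lower number that may not clear the scatter. Compound 3 is expected to give 1500 nM in this assay, within a range from 500 nM to 4500 nM.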

Compound 3, half-maximal inhibitory concentration: 910 nM
The estimate for compound 3 lay 1.6-fold (0.22 log units) above the measured number; the range from low to high includes it.
By their numbers in this assay, from the lowest: compounds 3 and 1 (each within the scatter of the next); then compound 2.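

In this assay, 3,4-dichlorophenyl in place of 4-methoxyphenyl, on the aromatic carbon opposite the ring nitrogen, gives a 2.5-fold lower number from compound 2 to compound 3 (0.40 log units; beyond the scatter). Within the data shown here, this is the first comparison that changes only one place, and it shows that the number responds to the group at this position even though both groups hold 8 heavy atoms and each is a six-membered aromatic ring of carbon only; the exchange replaces the oxygen of the leaving group, its 1 hydrogen-bond acceptor, with two chlorine atoms. Nothing available accounts for the direction or the size of this step, so the result stands as an observation about this one exchange.

As far as these compounds go, it remains open how a phenyl ring carrying a single chlorine, a phenyl ring carrying an amine or a carboxylic acid, or a pyridine ring would read at this position, so the contribution of each chlorine cannot yet be separated from that of the loss of the methoxy group. From the compounds shown here alone, it is also open whether the same exchange would give a similar step with a 4-nitrophenyl group in place of the 4-chlorophenyl group elsewhere on the molecule.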